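The source may report more compounds than this note shows. Statements on the series, on what has been measured and on what is new or still open speak of the compounds shown alone.

In an ADME assay for permeability, using PAMPA, with a stated time of 4 h, at pH 7.4, tested at 100 uM (on this read-out lower numbers stand for lower permeability and higher numbers for higher permeability), compound 2 `Cc1nc2cc(-c3cccc(OCc4ccccc4)c3)nn2c(-c2cc(F)c3c(c2C)CCCO3)c1C(OC(C)(C)C)C(=O)O` gives 570 nm/s. That number lies within the scatter of the two other measured compounds: compound 3 `Cc1nc2cc(-c3cccc(Oc4ccccc4)c3)nn2c(-c2cc(F)c3c(c2C)CCCO3)c1C(OC(C)(C)C)C(=O)O` gives 472 nm/s and compound 1 `Cc1nc2cc(-c3ccccc3)nn2c(N2CCC(C)(C)CC2)c1C(OC(C)(C)C)C(=O)O` gives 703 nm/s.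

Compound 4 `Cc1nc2cc(-c3cccc(OCc4ccccc4)c3)nn2c(N2CCC(C)(C)CC2)c1C(OC(C)(C)C)C(=O)O` has not yet been measured. It departs from compound 2 at one place: a group of 8 heavy atoms (7 carbon, 1 nitrogen; one six-membered non-aromatic ring with 1 hetero atom) in place of a group of 12 heavy atoms (10 carbon, 1 oxygen, 1 fluorine; one six-membered non-aromatic ring with 1 hetero atom, one six-membered aromatic ring of carbon only), on an aromatic carbon. The incoming group is 4,4-dimethylpiperidin-1-yl, and it sits on an aromatic carbon, ortho to a carboxy(tert-butoxy)methyl group.

Among the measured compounds shown here, no measured step covers this exchange. For the measured compounds named here, the one step available, a 1.2-fold lower number from compound 2 to compound 3 (0.08 log units; within the scatter), is a change of phenyl for benzyl on an oxygen at another place in the molecule, so it bears only on how little the numbers have moved so far. Closer evidence comes from compound 1, which already carries the 4,4-dimethylpiperidin-1-yl group and gives 703 nm/s. It also differs from compound 4 on the oxygen-bearing side, yet its value lies within the scatter of that of compound 2.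

No step beyond the scatter is therefore expected in this assay, and the expected step is a 1.1-fold higher number from compound 2 to compound 4 (0.04 log units; within the scatter). For compound 4 the estimated value is 620 nm/s, with an expected range from 310 nm/s to 1150 nm/s.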

Compound 4, apparent permeability: 375 nm/s
Compound 4: middle estimate off by 1.7-fold (0.22 log units), on the high side; measured number inside the range.
By their numbers in this assay, from the lowest: compounds 4, 3, 2 and 1 (each within the scatter of the next).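

On the aromatic carbon ortho to a carboxy(tert-butoxy)methyl group, with the benzyloxy group held constant, placing 4,4-dimethylpiperidin-1-yl where the group of 12 heavy atoms stood gives in this assay a 1.5-fold lower number from compound 2 to compound 4 (0.18 log units; within the scatter) and so leaves the number within the scatter. Benzyloxy in place of hydrogen on an aromatic carbon, now with 4,4-dimethylpiperidin-1-yl held constant, gives a 1.9-fold lower number from compound 1 to compound 4 (0.27 log units; within the scatter) and also stays within the scatter, so neither of these two single exchanges carries the read-out beyond the scatter among the compounds shown. No measurement given here offers an explanation for either step.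

Still open, from the compounds shown here alone, is whether other amines on this aromatic carbon, such as morpholin-4-yl or an open-chain dimethylamino group, would also stay within the scatter of compound 2, or whether a step beyond it would appear. Also open is what an exchange elsewhere would do, for example a primary amide in place of the carboxylic acid in the carboxy(tert-butoxy)methyl group, since every compound shown carries that same acid.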